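The source may hold more compounds than are shown below. What is called first, only, known or untested is meant among the compounds shown, and "the series" means these compounds.

For the measured compounds named here, in a functional assay on HepG2 cells (Homo sapiens) for antiproliferative activity, read by MTT assay, with a stated time of 72 h (on this read-out lower numbers stand for stronger inhibition and higher numbers for weaker inhibition), only two compounds sharing one core have been measured. Compound 1 `O=C1COc2ccc(-c3cccc(NS(=O)(=O)c4ccc(F)cc4)c3)cc2N1`, with hydrogen on an amide-type nitrogen in a ring, gives > 40000 nM, which is a limit of the assay and not a number. Going by the values given here, compound 2 `COc1ccc(N2C(=O)COc3ccc(-c4cccc(NS(=O)(=O)c5ccc(F)cc5)c4)cc32)cc1`, with 4-methoxyphenyl at that place, gives 29800 nM, the only actual number available in this assay. Compound 3 `O=C1COc2ccc(-c3cccc(NS(=O)(=O)c4ccc(F)cc4)c3)cc2N1C1CCCCC1` has cyclohexyl in place of 4-methoxyphenyl on the same nitrogen: cyclohexyl in place of 4-methoxyphenyl on an amide-type nitrogen in a ring. Among the compounds with values here, the only measured step at this place is an at least 1.3-fold lower number from compound 1 to compound 2 (0.12 log units; that floor lies within the scatter). Within the data shown here, it is open-ended and does not exceed the scatter, and no measured step compares the two groups directly. From the compounds shown here alone, on the basis of this step, no change beyond the scatter is expected in this assay, and the direction remains open. The estimated change is a 1.0-fold higher number from compound 2 to compound 3 (0.00 log units; within the scatter). A reading that reaches the limit of the assay would not be surprising. For compound 3 the expected value is 30000 nM, with an estimated range from 12000 nM to 60000 nM.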

Compound 3, half-maximal inhibitory concentration: 35900 nM
The estimate for compound 3 lay 1.2-fold (0.08 log units) below the measured number; the measured number falls inside the stated range.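

In this assay, the two groups on the amide-type nitrogen can now be compared directly, and cyclohexyl in place of 4-methoxyphenyl gives a 1.2-fold higher number from compound 2 to compound 3 (0.08 log units; within the scatter). The group that leaves carries an aromatic ring and a hydrogen-bond acceptor and the group that enters carries neither, yet this change does not separate the two compounds beyond the usual scatter. Cyclohexyl in place of hydrogen gives an at least 1.1-fold lower number from compound 1 to compound 3 (0.04 log units; that floor lies within the scatter), a second open-ended step whose floor adds no gain that can be read, since compound 1 stands at a limit and not at a number: the limit of > 40000 nM in this assay, at which 1 of the 3 values shown sits.

The compounds shown leave open whether any group on this nitrogen can move the number clearly away from that limit, since the hydrogen, the 4-methoxyphenyl and the cyclohexyl compounds give no difference that can be read beyond the scatter. From the compounds shown here alone, what a chain ending in an amine or a carboxylic acid would do at this place remains unknown, as does whether changes elsewhere on the shared core would have a larger effect on the number.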